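The compounds below may be only part of what the source reports. "The series", "measured", "known", "first", "only" and "open" are said of these compounds alone.

Compound 1 `Cc1cc(C)cc(S(=O)(=O)c2c(C(=O)NCC(=O)NCc3ccco3)[nH]c3ccc(Cl)cc23)c1`: > 50000 nM, a limit
Compound 2 `Cc1cc(C)cc(S(=O)(=O)c2c(C(=O)NCC(=O)NC(C)c3ccncc3)[nH]c3ccc(Cl)cc23)c1`: 47000 nM
Compound 3 `Cc1cc(C)cc(S(=O)(=O)c2c(C(=O)NC(C)c3ccco3)[nH]c3ccc(Cl)cc23)c1`: > 54700 nM, a limit

All three were tested in an ADME assay on MT4 cells (Homo sapiens) for cytotoxicity, read by MTT assay; on this read-out lower numbers stand for higher toxicity in this test and higher numbers for lower toxicity in this test. The value of compound 3 is a limit, > 54700 nM, and not a number. Compound 4 `Cc1cc(C)cc(S(=O)(=O)c2c(C(=O)NCc3ccc4nc(N)[nH]c4c3)[nH]c3ccc(Cl)cc23)c1` differs from it on the amide-type nitrogen: a group of 11 heavy atoms (8 carbon, 3 nitrogen; one five-membered aromatic ring with 2 hetero atoms, one six-membered aromatic ring of carbon only) in place of a group of 7 heavy atoms (6 carbon, 1 oxygen; one five-membered aromatic ring with 1 hetero atom), on an amide-type nitrogen. Two measured changes at that nitrogen can be read only as floors: an at least 1.0-fold lower number from compound 1 to compound 2 (0.02 log units; that floor lies within the scatter), and an at least 1.1-fold higher number from compound 2 to compound 3 (0.06 log units; that floor lies within the scatter). The third gives a step that the two limits leave unreadable from compound 1 to compound 3. None of them involves the group that enters here, so the guide is weak. Only compound 2, at 47000 nM, has a true number, and the expectation is anchored on it. A modest move to a lower number is expected, with an estimated step of an at least 1.8-fold lower number from compound 3 to compound 4 (0.26 log units; that floor lies within the scatter). Compound 4 is expected to give about 30000 nM, with an estimated range of 9000 nM to 60000 nM.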

Compound 4, half-maximal cytotoxic concentration: 5890 nM
Compound 4: middle estimate off by 5.1-fold (0.71 log units), on the high side, and the stated range ends above it.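

Among the compounds shown here, with the group carrying the 2-amino-1H-benzimidazol-6-yl ring pair on the amide-type nitrogen, this assay gives the first steps beyond the scatter: an at least 9.2-fold lower number from compound 3 to compound 4 (0.96 log units; beyond the scatter), an 8.0-fold lower number from compound 2 to compound 4 (0.90 log units; beyond the scatter) and an at least 8.4-fold lower number from compound 1 to compound 4 (0.92 log units; beyond the scatter). Among compounds 1, 2 and 3, with their furan and pyridine groups, no readable step went beyond the scatter, so this position does respond to the group it carries. Nothing shown accounts for the fall in the number.

As far as these compounds go, whether the step follows the amine of this group or its two rings stays open. A benzyl group or a 1H-benzimidazol-6-yl group without the amine, at the same nitrogen, would bear on that.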